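This account rests on a few compounds, and the source may have more. Where it says the series, first, only, none or still open, it means among the compounds named here.

Compound 1, `COc1ccc2[nH]c3c4cn[nH]c4c4c(c3c2c1)C(=O)NC4=O`, and compound 2, `Cc1ccc2[nH]c3c4cn[nH]c4c4c(c3c2c1)C(=O)NC4=O`, share one core, while compound 3, `COc1ccc2[nH]c(-n3cccn3)cc2c1`, and compound 4, `Cc1ccc2[nH]c(-n3cccn3)cc2c1`, share another; the difference between the two cores is not broken down here. In a functional assay on U-373MG ATCC cells (Homo sapiens) for cytotoxicity, read by MTT assay, with a stated time of 72 h (on this read-out higher numbers stand for weaker inhibition and lower numbers for stronger inhibition), compound 1 gives 51000 nM. For compound 2 this assay reports only a limit, > 100000 nM. For compound 3 this assay likewise reports only a limit, > 100000 nM. The change from compound 1 to compound 2 is methyl in place of methoxy on an aromatic carbon, and it gives an at least 1.9-fold higher number from compound 1 to compound 2 (0.29 log units; that floor lies within the scatter), a reading that rests on (the limit of > 100000 nM in this assay, at which 2 of the 3 values shown sit). The change from compound 3 to compound 4 is methyl in place of methoxy on an aromatic carbon; it is the same kind of change, though its place is part of a fused or bridged system of two rings rather than five. Since compound 3 sits at the limit as shown by > 100000 nM, compound 4 is expected to sit there as well, with an estimated step that the limit leaves unreadable from compound 3 to compound 4. The estimate for compound 4 in this assay is 150000 nM, between 50000 nM and 500000 nM.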

Compound 4, half-maximal inhibitory concentration: > 100000 nM
Compound 4 ended at the assay's limit; the forecaster's own chance of this, stated with the estimate: 85%; the middle value does not contradict the limit.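

Compound 3 and compound 4 both stand only at a limit in this assay, so the step of methyl in place of methoxy between them cannot be read, because neither gives a number: the limit of > 100000 nM in this assay, at which 3 of the 4 values shown sit.

The compounds shown leave open whether this change does anything at all on the core of compound 3.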